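Working notes: trifluoromethoxy in place of chloro

The source may hold more compounds than are shown below. What is called first, only, known or untested is meant among the compounds shown, and "the series" means these compounds.

Compound 1 `C=C(Br)C(=O)Nc1cccc(/C=C/C(=O)Nc2ccc(Cl)cc2)c1`: 460 nM
Compound 2 `C=C(Br)C(=O)Nc1cccc(/C=C/C(=O)NCc2ccc(C)cc2)c1`: 550 nM

Both compounds were tested in a functional assay on CCRF-CEM cells (Homo sapiens) for inhibition, read by MTT assay, with a stated time of 72 h; a lower number here means a stronger inhibitor, a higher number a weaker inhibitor. Within the data shown here, compound 1 has only one measured neighbour, and the gap to it is a 1.2-fold higher number from compound 1 to compound 2 (0.08 log units; within the scatter), so the two cannot be ranked. The next compound, compound 3 `C=C(Br)C(=O)Nc1cccc(/C=C/C(=O)Nc2ccc(OC(F)(F)F)cc2)c1`, carries this change: trifluoromethoxy in place of chloro on an aromatic carbon. Trifluoromethoxy replaces chloro on an aromatic carbon, para to a large group. Among the measured compounds shown here, the single measured step swaps 4-chlorophenyl for 4-methylbenzyl on an amide-type nitrogen, so it bears only indirectly on this swap. For the measured compounds named here, no measured pair isolates the chloro position. With that one step within the scatter, no step beyond the scatter is expected in this assay. The expected step is a 1.0-fold lower number from compound 1 to compound 3 (0.01 log units; within the scatter). The estimate for compound 3 is 450 nM, with an expected range of 180 nM to 1100 nM.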

Compound 3, half-maximal inhibitory concentration: 13000 nM
The estimate for compound 3 lay 29-fold (1.46 log units) below the measured number, outside the stated range (above it).
By their numbers in this assay, from the lowest: compounds 1 and 2 (each within the scatter of the next); then compound 3.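

In this assay, the position on the aromatic carbon para to a large group proves sensitive: trifluoromethoxy in place of chloro gives a 28-fold higher number from compound 1 to compound 3 (1.45 log units; beyond the scatter), a large loss that the earlier step between compounds, which stayed within the scatter, gave no sign of. Chloro and trifluoromethoxy are therefore not interchangeable at this position on the core of compound 1, although the change adds only 5 heavy atoms for 1 and a single hydrogen-bond acceptor. No measurement available here explains the loss.

Open, from the compounds shown here alone, is which part of the trifluoromethoxy group carries the loss; methoxy or trifluoromethyl on the same carbon would separate the oxygen from the fluorine atoms. Also open, going by these compounds, is whether the same change costs as much on the benzyl amide of compound 2.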